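The source may report more compounds than this note shows. Statements on the series, on what has been measured and on what is new or still open speak of the compounds shown alone.

Compound 1 `N/C(=N\NC(=S)N1CCOCC1)c1ccccn1` carries a morpholin-4-yl group on its thiocarbonyl carbon. In a functional assay on HeLa cells (Homo sapiens) for cytotoxicity, read by MTT assay, with a stated time of 72 h, tested at 3 uM (a higher number here means more inhibition of growth at the concentration tested, a lower number less inhibition of growth), compound 1 gives 40%. Compound 2 `N/C(=N\NC(=S)N1CCCCC1)c1ccccn1` differs from it in one place piperidin-1-yl in place of morpholin-4-yl on a thiocarbonyl carbon and in this assay compound 2 gives 49.2%, so that a number 9.2 percentage points higher from compound 1 to compound 2 (within the scatter). Compound 3 `Cc1cccc(/C(N)=N/NC(=S)N2CCOCC2)n1` has a different core, which differs from the core of compound 1 in one place (methyl in place of hydrogen on an aromatic carbon), and in this assay compound 3 gives 65.7%, so that a number 25.7 percentage points higher from compound 1 to compound 3 (beyond the scatter).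

Compound 4 `Cc1cccc(/C(N)=N/NC(=S)N2CCCCC2)n1` has not yet been measured. It stands to compound 3 as compound 2 stands to compound 1, with the same change in the same place (piperidin-1-yl in place of morpholin-4-yl on a thiocarbonyl carbon). Since the first time this change was made gave only a small step, within the usual scatter, the expectation is a step of similar size on the new core, so that a number 7.3 percentage points higher from compound 3 to compound 4 (within the scatter) is estimated, resting on a number 9.2 percentage points higher from compound 1 to compound 2 (within the scatter). Compound 4 is therefore expected to give about 73%, most likely between 60% and 85%.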

Compound 4, percent growth inhibition at one concentration: 68.9%
For compound 4 the middle estimate is 4.1 percentage points above the measured one, within the range that was stated.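

In this assay, within the data shown here, piperidin-1-yl in place of morpholin-4-yl on the thiocarbonyl carbon gives, on the methyl-bearing core, a number 3.2 percentage points higher from compound 3 to compound 4 (within the scatter), so this swap again produces no step that stands out from the scatter, and the two cores agree: the same change on two cores in this assay, a number 9.2 percentage points higher (within the scatter) from compound 1 to compound 2 and a number 3.2 percentage points higher (within the scatter) from compound 3 to compound 4, 6 percentage points apart, within the scatter of two such steps. Methyl in place of hydrogen on an aromatic carbon, now with piperidin-1-yl in place, gives a number 19.7 percentage points higher from compound 2 to compound 4 (beyond the scatter), so this change also carries over and remains the larger of the two: the same change on two cores in this assay, a number 25.7 percentage points higher (beyond the scatter) from compound 1 to compound 3 and a number 19.7 percentage points higher (beyond the scatter) from compound 2 to compound 4, 6 percentage points apart, within the scatter of two such steps. This shows that each change behaved alike in these two pairs of compounds, but it does not show that the swap itself alters growth inhibition, nor that either step would hold on any other core or in other cells.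

On these data alone, it remains open whether a piperazine or an open-chain dimethylamino group on the thiocarbonyl carbon would follow the same pattern. As far as these compounds go, it is equally open whether an ethyl group or a chlorine atom could stand in for the methyl and give a similar step.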